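A few compounds are considered here, and "the series" means these few. Any claim that something is new, unique, unknown or untested is made for them only; others in the source may bear on it.

This account concerns a set of compounds built on the shared core of compound 1 `Cc1cn(C2CCN(Cc3cccc(Oc4cc(F)cc(F)c4)c3)CC2)c(=O)[nH]c1=O` and tested in an ADME assay on MRC5 cells (Homo sapiens) for cytotoxicity, read by fluorescence and resazurin assay, with a stated time of 3 days; a higher number here means a weaker inhibitor, a lower number a stronger inhibitor. In this assay compound 1 gives > 64000 nM, which is a limit of the assay and not a number. Compound 2 `Cc1cn(C2CCN(Cc3cccc(Oc4ccccc4)n3)CC2)c(=O)[nH]c1=O` belongs to the same set. In this assay compound 2 gives > 64000 nM, again a limit rather than a number. Compound 3 `Cc1cn(C2CCN(Cc3cc(Oc4cc(Cl)cc(Cl)c4)ccn3)CC2)c(=O)[nH]c1=O` also belongs to the set; in this assay compound 3 gives "not determined" (no result reported), so no value is available for it. Compound 1 thus stands at the limit of > 64000 nM in this assay, at which 2 of the 3 values shown sit, and nothing in the figures separates it from compound 2. Among the compounds with values here, no step between two measured compounds can be read from these data.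

The compound still to be measured is compound 4 `Cc1cn(C2CCN(Cc3cccc(OC4CCCC4)c3)CC2)c(=O)[nH]c1=O`, which differs from compound 1 by cyclopentyl in place of 3,5-difluorophenyl on an oxygen on an aromatic ring. Since every measured value sits at the limit, the expected step in this assay is a step that the limit leaves unreadable from compound 1 to compound 4, none beyond the scatter. Compound 4 is estimated at 80000 nM in this assay, within 40000 nM to 200000 nM, and it is expected that the assay will once more report only a limit for compound 4.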

Compound 4, half-maximal inhibitory concentration: 30300 nM
The estimate for compound 4 lay 2.6-fold (0.42 log units) above the measured number; the measured number lies below the stated range.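

Within the data shown here, compound 4 is the first compound of the set to give a number in this assay, where the earlier compounds offered only a limit or no result: the limit of > 64000 nM in this assay, at which 2 of the 4 values shown sit. Cyclopentyl in place of 3,5-difluorophenyl on an oxygen on an aromatic ring gives an at least 2.1-fold lower number from compound 1 to compound 4 (0.32 log units; beyond the scatter), so a change at this position can move the read-out beyond the scatter. Compound 1 gives only a limit, so the step has a known minimum but no known full size.

This single pair cannot tell whether the lower number goes with the non-aromatic ring, with the ring size or with the loss of fluorine. The compounds shown also leave open how an amine, a carboxylic acid or a longer alkyl chain on that oxygen would read in this assay.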